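From vinyl to 4-methylphenyl at the assay limit

A few compounds are considered here, and "the series" means these few. Any claim that something is new, unique, unknown or untested is made for them only; others in the source may bear on it.

Compound 1 (`C=CCn1c(N)c(C#N)c2c(N)ncnc21`) was tested in a functional assay on KB cells (Homo sapiens) for inhibition (on this read-out lower numbers stand for stronger inhibition and higher numbers for weaker inhibition), and gives > 100000 nM as a limit, not a number. Compound 2 (`CCOCn1c(N)c(C(N)=O)c2c(N)ncnc21`) gives > 100000 nM in the same test, also a limit. Compound 3 (`CCOCn1cc(C#N)c2c(N)ncnc21`) gives > 100000 nM as a limit too. Compound 1 therefore stands at the limit of > 100000 nM in this assay, at which 3 of the 3 values shown sit, and offers no true number to start from.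

Compound 4 (`Cc1ccc(Cn2c(N)c(C#N)c3c(N)ncnc32)cc1`) has 4-methylphenyl in place of vinyl on a saturated chain carbon bound to an aromatic nitrogen. Within the data shown here, no measured step can guide this change, so the expected shift is an at least 1.2-fold lower number from compound 1 to compound 4 (0.09 log units; that floor lies within the scatter) and only a small one towards stronger inhibition. Compound 4 is estimated at 80000 nM with an expected range from 15000 nM to 300000 nM in this test.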

Compound 4, half-maximal inhibitory concentration: > 100000 nM
Compound 4: only a limit was reported; the forecaster's own chance of this, stated with the estimate: 60%; at least 1.2-fold (0.09 log units) between middle value and limit.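

Compound 1 and compound 4 both sit at a limit rather than a true number, so no step can be read between them: the limit of > 100000 nM in this assay, at which 4 of the 4 values shown sit.

Going by these compounds, whether 4-methylphenyl in place of vinyl changes inhibition at all, and by how much, stays open.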